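Trimming the amine substituent toward methyl

The source may hold more compounds than are shown below. What is called first, only, known or untested is meant among the compounds shown, and "the series" means these compounds.

Three compounds share one core and differ only in the group on an amine nitrogen. In an ADME assay on microsomes from liver (Homo sapiens) for metabolic stability, read by LC-MS, with a stated time of 10 min (on this read-out higher numbers stand for a more stable compound and lower numbers for a less stable compound), compound 1 `CN(C[C@@H]1Cc2c(cccc2N2CCNCC2)CN1)[C@H]1CCCc2cccnc21` gives 94.2%, compound 2 `FC1(F)CCC(CN(C[C@H]2Cc3c(cccc3N3CCNCC3)CN2)[C@H]2CCCc3cccnc32)CC1` gives 68.6%, and compound 3 `CC(C)N(C[C@H]1Cc2c(cccc2N2CCNCC2)CN1)[C@H]1CCCc2cccnc21` gives 75%. Compound 3 stands second highest of the three; its gap to compound 2 is within the scatter, while compound 1 sits beyond the scatter above it. For the measured compounds named here, the one measured step that bears on a change of this kind, a number 6.4 percentage points higher from compound 2 to compound 3 (within the scatter), shows that a smaller group on this nitrogen went with a value that was not distinguishable from the larger one. Compound 4 `CN(C[C@H]1Cc2c(cccc2N2CCNCC2)CN1)[C@H]1CCCc2cccnc21` carries methyl in place of isopropyl on an amine nitrogen. Compound 1 also bears a methyl on that nitrogen and gives the highest value seen, so a rise beyond the scatter is plausible, though the step from compound 2 to compound 3 alone would predict little. For compound 4 the expected step is a number 11 percentage points higher from compound 3 to compound 4 (beyond the scatter) in this assay. Compound 4 is therefore estimated at 86%, within a range from 72% to 97%.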

Compound 4, percent of the compound remaining: 99.7%
Compound 4: middle estimate off by 13.7 percentage points, on the low side; measured number above the stated range.
By their numbers in this assay, from the lowest: compounds 2 and 3 (each within the scatter of the next); then compounds 1 and 4 (each within the scatter of the next).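

In this assay, methyl in place of isopropyl on this amine nitrogen gives a clear rise (a number 24.7 percentage points higher from compound 3 to compound 4 (beyond the scatter)), so shortening the group here does make a difference, which the step from compound 2 to compound 3 could not show. Hydrogen in place of 4,4-difluorocyclohexyl on the saturated chain carbon bound to this nitrogen gives a larger rise (a number 31.1 percentage points higher from compound 2 to compound 4 (beyond the scatter)), which sets the methyl compound apart from both larger groups drawn with the same configuration. Changing the configuration at the saturated ring carbon leaves no readable difference (a number 5.5 percentage points higher from compound 1 to compound 4 (within the scatter)), and this pair isolates that one change: the fact that compounds 1 and 4 differ only in the configuration as drawn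

The compounds shown leave open whether an ethyl group or a cyclopropyl group on this nitrogen would stay level with compound 4. They also leave open whether the configuration at that ring carbon would matter with isopropyl on the nitrogen.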